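The compounds below may be only part of what the source reports. "The series", "measured", "known", "first", "only" and "open" are said of these compounds alone.

In a physicochemical assay for lipophilicity (on this read-out higher numbers stand for higher lipophilicity and lower numbers for lower lipophilicity), three compounds sharing one core have been measured. Compound 1 `C=C(c1ccc2ccccc2c1)C1CCC2(CC1)COC(Nc1ccccc1)OO2` gives 5.59, compound 2 `C=C(c1ccc2ccccc2c1)C1CCC2(CC1)COC(Nc1ccc(Cl)cc1)OO2` gives 6.15, and compound 3 `C=C(c1ccc2ccccc2c1)C1CCC2(CC1)COC(Nc1ccccc1-c1ccccc1)OO2` gives 7.26, the highest of the three and clear of the scatter against both others. Compound 4 `C=C(c1ccc2ccccc2c1)C1CCC2(CC1)COC(Nc1cccc(C(F)(F)F)c1)OO2` has 3-(trifluoromethyl)phenyl in place of 2-phenylphenyl on an amine nitrogen.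

Within the data shown here, three measured steps bear on this change. The large a number 1.67 log units higher from compound 1 to compound 3 (beyond the scatter) came with phenyl in place of hydrogen on an aromatic carbon, and that phenyl is lost on the way to compound 4. The modest a number 0.56 log units higher from compound 1 to compound 2 (beyond the scatter) came with chloro in place of hydrogen on an aromatic carbon, the nearest measured case of a small substituent. The large a number 1.11 log units higher from compound 2 to compound 3 (beyond the scatter) is the closest swap in kind, run in the opposite direction. Among the measured compounds shown here, no trifluoromethyl compound has been measured, so compound 4 is placed by analogy, near compound 2. A clear fall is expected, of about the size of that last step, and the estimate is a number 0.86 log units lower from compound 3 to compound 4 (beyond the scatter). The expected value for compound 4 is 6.4, in an estimated range from 6 to 6.9.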

Compound 4, partition coefficient: 6.51
For compound 4 the middle estimate is 0.11 log units below the measured one, within the range that was stated.
By their numbers in this assay, from the lowest: compound 1; then compound 2; then compound 4; then compound 3.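

In this assay, trifluoromethyl on the aromatic ring gives a second substituted single-ring case to set against the unsubstituted phenyl, with a number 0.92 log units higher from compound 1 to compound 4 (beyond the scatter). The two single-ring substituted groups also separate from each other, with a number 0.36 log units higher from compound 2 to compound 4 (beyond the scatter), while the 2-phenylphenyl group, with its two aromatic rings, stays ahead, with a number 0.75 log units lower from compound 3 to compound 4 (beyond the scatter). Nothing available gives a measured reason for any of these steps.

Both the substituent and its place on the ring differ between the 4-chlorophenyl and 3-(trifluoromethyl)phenyl groups, so these compounds cannot show how much of that step belongs to each. On these data alone, it also remains open where a nitrile or a carboxylic acid on the same aromatic ring would fall on this scale.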